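Widening the Aniline Ring Substituent: Caco-2 Permeability Outlook

A few compounds are considered here, and "the series" means these few. Any claim that something is new, unique, unknown or untested is made for them only; others in the source may bear on it.

Compound 1 `CNC(=O)c1cc(Oc2ccc3oc(Nc4ccccc4Cl)nc3c2)ccn1`: 10 10^-6 cm/s
Compound 2 `CCc1ccccc1Nc1nc2cc(Oc3ccnc(C(=O)NC)c3)ccc2o1`: 10 10^-6 cm/s
Compound 3 `CNC(=O)c1cc(Oc2ccc3oc(Nc4ccc(C(C)C)cc4)nc3c2)ccn1`: 10 10^-6 cm/s

These three compounds share one core and differ only on the aniline ring. In an ADME assay on Caco-2 cells (Homo sapiens) for permeability, in the apical to basolateral direction (on this read-out lower numbers stand for lower permeability and higher numbers for higher permeability), compound 3 sits level with compounds 1 and 2; the steps of no change at the digits printed from compound 1 to compound 2 (within the scatter), no change at the digits printed from compound 1 to compound 3 (within the scatter) and no change at the digits printed from compound 2 to compound 3 (within the scatter) all stay within the scatter. Compound 4 `CCN1CCN(c2ccc(Nc3nc4cc(Oc5ccnc(C(=O)NC)c5)ccc4o3)cc2)CC1` takes the change (4-ethylpiperazin-1-yl in place of isopropyl on an aromatic carbon). The measured steps swapped only small carbon groups or a halogen and say nothing about bringing in a second ring with two hydrogen-bond acceptors, so they give weak guidance. Compound 4 is therefore expected to show a modest downward step a 2.0-fold lower number from compound 3 to compound 4 (0.30 log units; within the scatter), and its estimated value in this assay is 5 10^-6 cm/s, within 1.5 10^-6 cm/s to 15 10^-6 cm/s.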

Compound 4, apparent permeability: 10 10^-6 cm/s
The estimate for compound 4 lay 2.0-fold (0.30 log units) below the measured number, and the stated range covers the measured number.
By their numbers in this assay, from the lowest: compounds 1, 2, 3 and 4 (each within the scatter of the next).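

In this assay, putting 4-ethylpiperazin-1-yl in place of isopropyl gives no change at the digits printed from compound 3 to compound 4 (within the scatter). So on this aromatic carbon, the reading also holds level for a much larger group, one that brings a six-membered non-aromatic ring and 2 hydrogen-bond acceptors, whereas the earlier steps exchanged only small groups and whole substituted phenyl rings. No measurement at hand explains this result. Still open, going by these compounds, is whether a carboxylic acid, or a longer chain ending in an amine, at this same place would also stay level in this assay.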